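The compounds below may be only part of what the source reports. "The series", "measured", "known", "first", "only" and "open" are said of these compounds alone.

Measured in a functional assay on a cell-free system (Platelet, plasma, Oryctolagus cuniculus) for inhibition, with a stated time of 5 min; on this read-out higher numbers stand for weaker inhibition and lower numbers for stronger inhibition:

Compound 1 `CCOC(=O)/C=C/c1cc(Br)c(OCc2nc(C)c(C)nc2C)c(Br)c1`: > 2000000 nM (a limit, not a number)
Compound 2 `Cc1nc(C)c(COc2ccc(/C=C/C(=O)O)cc2)nc1C`: 1400000 nM
Compound 3 `COc1cccc(/C=C/C(=O)O)c1OCc1nc(C)c(C)nc1C`: 522000 nM

Compound 1 has only a limit and no number in this assay: the limit of > 2000000 nM in this assay, at which 1 of the 3 values shown sits. Compound 4 `Cc1nc(C)c(COc2c(Br)cc(/C=C/C(=O)O)cc2Br)nc1C` differs from compound 1 in one place, with hydrogen in place of ethyl on an oxygen next to a carbonyl group, so that ethoxycarbonyl becomes carboxy (hydrogen in place of ethyl on an oxygen next to a carbonyl group). Among the compounds with values here, no pair of measured compounds shows this change on its own, so its size can only be judged indirectly. Compound 2 carries the 2-carboxyethenyl group and gives 1400000 nM. Compound 3 carries the same group and gives 522000 nM. On the strength of these two numbers, compound 4 is expected to read lower than the limit of compound 1, meaning stronger inhibition, though still weak in absolute terms. The expected change is an at least 2.8-fold lower number from compound 1 to compound 4 (0.45 log units; beyond the scatter). The estimated value for compound 4 is 700000 nM, with an expected range from 200000 nM to 2000000 nM.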

Compound 4, half-maximal inhibitory concentration: 1290000 nM
The estimate for compound 4 lay 1.8-fold (0.27 log units) below the measured number, and the stated range covers the measured number.
By their numbers in this assay, from the lowest: compound 3; then compounds 4 and 2 (each within the scatter of the next). At a limit, above all of these: compound 1.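

In this assay, within the data shown here, the change from ethoxycarbonyl to carboxy now stands as a step of its own, which reads an at least 1.5-fold lower number from compound 1 to compound 4 (0.19 log units; that floor lies within the scatter) and is the first direct reading of this change. Compound 4 gives 1290000 nM as a true number, so with hydrogen in place of ethyl on this oxygen the core of compound 1 reads within the measured range, though inhibition remains weak in absolute terms. Only a floor can be given for the step, because its starting point is a limit and not a number: the limit of > 2000000 nM in this assay, at which 1 of the 4 values shown sits.

From the compounds shown here alone, the true size of the step remains open, as does whether the same change acts alike on the cores of compound 2 and compound 3. Also open, going by these compounds, is how a primary amide or a longer chain ending in a carboxylic acid would read in place of the carboxy group of compound 4.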